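Swapping the group on the nitrogen of compound 1

The source may hold more compounds than are shown below. What is called first, only, known or untested is meant among the compounds shown, and "the series" means these compounds.

In a functional assay on MCF7 cells (Homo sapiens) for cytotoxicity, read by sulforhodamine B assay, with a stated time of 48 h (on this read-out lower numbers stand for stronger inhibition and higher numbers for weaker inhibition), compound 1 (`N#Cc1c(-c2ccc(Cl)cc2)cc(-c2ccc(Cl)cc2)n(CC(O)CCl)c1=O`) gives 4.6 ug/mL and compound 2 (`N#Cc1c(-c2ccc(Cl)cc2)cc(-c2ccc(Cl)cc2)n([C@@H]2O[C@H](COC(=O)c3ccccc3)[C@@H](OC(=O)c3ccccc3)[C@H]2OC(=O)c2ccccc2)c1=O`) gives 5.9 ug/mL, two values within the usual scatter of each other. Compound 3 (`N#Cc1c(-c2ccc(Cl)cc2)cc(-c2ccc(Cl)cc2)n([C@@H]2O[C@H](CO)[C@@H](O)[C@H](O)[C@H]2O)c1=O`) keeps the core of compound 1 but changes the group on an aromatic nitrogen: 3,4,5-trihydroxy-6-(hydroxymethyl)oxan-2-yl in place of 3-chloro-2-hydroxypropyl on an aromatic nitrogen. For the measured compounds named here, no measured pair shows this change directly. Compound 2 shares the core, carries a very different group there and still gives 5.9 ug/mL. On that evidence, only a modest move toward weaker inhibition is expected, a 1.7-fold higher number from compound 1 to compound 3 (0.24 log units; within the scatter). The estimated value for compound 3 is 8 ug/mL, with an expected range from 3 ug/mL to 25 ug/mL.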

Compound 3, half-maximal inhibitory concentration: 14.2 ug/mL
Beside the measured number, compound 3's estimate is 1.8-fold (0.25 log units) below it; the range from low to high includes it.
By their numbers in this assay, from the lowest: compounds 1 and 2 (each within the scatter of the next); then compound 3.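

For the compounds shown here, at the aromatic nitrogen, the earlier compounds gave no step beyond the scatter, but in this assay putting 3,4,5-trihydroxy-6-(hydroxymethyl)oxan-2-yl in place of 3-chloro-2-hydroxypropyl gives a 3.1-fold higher number from compound 1 to compound 3 (0.49 log units; beyond the scatter) and so a modest loss of inhibition. This position therefore responds to the choice of group. Nothing available explains this shift. The compounds shown do not separate the loss of the chlorine from the arrival of the ring with its hydroxyl groups. Going by these compounds, how a plain propyl chain or a 3-aminopropyl group on this nitrogen would read also stays open.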